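Swapping a Butyl Chain for a Cyclopentyl Ring

The source may hold more compounds than are shown below. What is called first, only, known or untested is meant among the compounds shown, and "the series" means these compounds.

Compound 1 `CCCCc1csc(CN[C@@H]2C[C@H]3C[C@@H]([C@H]2C)C3(C)C)c1` was tested in an ADME assay on MDCK cells (Canis lupus familiaris) for cytotoxicity, read by microscopy, with a stated time of 48 h (a lower number here means that less compound is tolerated, a higher number that more compound is tolerated), where compound 1 gives 12500 nM. Among the compounds with values here, this is the only real number among the two results gathered so far. Compound 2 `C[C@H]1[C@H](NCc2ccoc2)C[C@H]2C[C@@H]1C2(C)C` reached only a limit of the assay: in this assay compound 2 gives > 100000 nM. Of the two results, one thus sits at the limit of > 100000 nM in this assay, at which 1 of the 2 values shown sits, so compound 1 stands alone as the single measured concentration.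

Compound 3 `C[C@H]1[C@H](NCc2cc(C3CCCC3)cs2)C[C@H]2C[C@@H]1C2(C)C` has not been measured. It differs from compound 1 by cyclopentyl in place of butyl on an aromatic carbon. Within the data shown here, no pair of measured compounds that differ in a single place is available, so no step of known size exists to lean on. The step of no change at the digits printed from compound 1 to compound 3 (within the scatter) is expected to be small, staying within the usual scatter of this kind of measurement. Compound 3 is therefore estimated at 12500 nM, with a range from 5000 nM to 40000 nM.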

Compound 3, minimum cytotoxic concentration: 1560 nM
Beside the measured number, compound 3's estimate is 8.0-fold (0.90 log units) above it; measured number below the stated range.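

In this assay, within the data shown here, the swap of butyl for cyclopentyl gives an 8.0-fold lower number from compound 1 to compound 3 (0.90 log units; beyond the scatter) and so provides the first step of known size in this set. It shows that the aromatic carbon two ring bonds from the ring sulfur is sensitive to the group it carries: on the core of compound 1, replacing the open chain with a five-membered ring of carbon moves the number beyond the scatter, and less compound is tolerated. Nothing measured here accounts for this change.

The compounds shown leave open whether the ring or the added carbon carries the step, a question that a pentyl chain on the same aromatic carbon would address. On these data alone, how an amine or a carboxylic acid at this place would read in this assay also remains open.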